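The source may report more compounds than this note shows. Statements on the series, on what has been measured and on what is new or still open speak of the compounds shown alone.

Measured in a functional assay on T29Kt1 cells (Homo sapiens) for cytotoxicity, read by sulforhodamine B assay, with a stated time of 3 days; a lower number here means a stronger inhibitor, a higher number a weaker inhibitor:
- compound 1 `OCc1cn(Cc2cccc(I)c2)c2ccccc12`: 20 nM
- compound 2 `OCc1cn(Cc2cccc(C(F)(F)F)c2)c2ccccc12`: 560 nM
- compound 3 `Cc1cccc(Cn2cc(CO)c3ccccc32)c1`: 1000 nM

Compound 3 lies within the scatter of compound 2, as a 1.8-fold higher number from compound 2 to compound 3 (0.25 log units; within the scatter) shows, and both lie far from the iodo compound, as a 50-fold higher number from compound 1 to compound 3 (1.70 log units; beyond the scatter) shows. The next analogue, compound 4 `O=[N+]([O-])c1cccc(Cn2cc(CO)c3ccccc32)c1`, carries nitro in place of methyl on an aromatic carbon, meta to a large group (nitro in place of methyl on an aromatic carbon).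

For the measured compounds named here, no nitro compound has been measured, so the steps available bear on this change only indirectly. Two of them are large: a 28-fold higher number from compound 1 to compound 2 (1.45 log units; beyond the scatter) and a 50-fold higher number from compound 1 to compound 3 (1.70 log units; beyond the scatter). The third, the exchange of trifluoromethyl for methyl, stays within the scatter. Among these three compounds, only compound 1 stands apart, so one group in three gave a large shift. The expectation in this assay therefore follows the pair of compound 2 and compound 3: a small step, probably not beyond the scatter, with a slight lean towards a lower number. Compound 1 at 20 nM keeps open the chance of a much larger drop, so the range stays wide.

The expected change is a 1.7-fold lower number from compound 3 to compound 4 (0.22 log units; within the scatter). The estimate for compound 4 is 600 nM, with an expected range from 150 nM to 2000 nM.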

Compound 4, half-maximal inhibitory concentration: 390 nM
Compound 4: the middle estimate sits 1.5-fold (0.19 log units) above what was measured; the measured number falls inside the stated range.
By their numbers in this assay, from the lowest: compound 1; then compounds 4, 2 and 3 (each within the scatter of the next, the first and the last beyond it).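

In this assay, nitro on this aromatic carbon, meta to a large group, separates from methyl by a modest margin, with a 2.6-fold lower number from compound 3 to compound 4 (0.41 log units; beyond the scatter), whereas trifluoromethyl had stayed within the scatter of methyl. Nitro and trifluoromethyl cannot be told apart here, given a 1.4-fold lower number from compound 2 to compound 4 (0.16 log units; within the scatter), and neither approaches iodo: the exchange for nitro still leaves a 20-fold higher number from compound 1 to compound 4 (1.29 log units; beyond the scatter), so iodo remains the one group of the four that stands far from the others at this position. The data offer no measured property that would account for either the modest separation of nitro from methyl or the distance of iodo from the other three groups.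

The compounds shown leave open whether bromo or chloro on the same aromatic carbon would come close to iodo or fall with the other three groups, which would show how particular the result for iodo is. They also leave open how an amine or a carboxylic acid would behave at this place, and whether iodo keeps its lead when moved to another carbon of the same ring.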